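Deprotecting the Dioxolane: What Compound 4 May Show

A few compounds are considered here, and "the series" means these few. Any claim that something is new, unique, unknown or untested is made for them only; others in the source may bear on it.

Of the compounds shown here, three sharing one core have been measured in a toxicity assay on L02 cells (Homo sapiens) for cytotoxicity, read by MTT assay, with a stated time of 72 h; a lower number here means a stronger inhibitor, a higher number a weaker inhibitor. Compound 1 `CN1CCN(CCCCCCn2c3c(c4ccccc42)C(=O)c2c[n+]([O-])c4ccccc4c2C3=O)CC1` gives 3800 nM, and compound 2 `CN1CCN(CCCCCn2c3c(c4ccccc42)C(=O)c2c[n+]([O-])c4ccccc4c2C3=O)CC1` gives 1640 nM, a change of a 2.3-fold lower number from compound 1 to compound 2 (0.36 log units; beyond the scatter). Compound 3 `CC1(C)O[C@@H](CO)[C@H](Cn2cc(Cn3c4c(c5ccccc53)C(=O)c3c[n+]([O-])c5ccccc5c3C4=O)nn2)O1` gives 500 nM, the lowest of the three numbers and beyond the scatter from both others.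

Compound 4 `O=C1c2c[n+]([O-])c3ccccc3c2C(=O)c2c1c1ccccc1n2Cc1cn(CC(O)CO)nn1` differs from compound 3 in one place: 1,2-dihydroxyethyl in place of 5-(hydroxymethyl)-2,2-dimethyl-1,3-dioxolan-4-yl on a saturated chain carbon bound to an aromatic nitrogen. Within the data shown here, no measured step concerns this kind of change; the only step recorded, between compound 1 and compound 2, concerns the length of the chain, not the group at the chain's end, and it was modest. With nothing in the data that speaks to opening a dioxolane into a diol, the account expects compound 4 to stay close to compound 3 in this assay, with a step of a 1.2-fold higher number from compound 3 to compound 4 (0.08 log units; within the scatter) that is not expected to exceed the scatter. The estimate for compound 4 is therefore 600 nM, within a range from 250 nM to 1500 nM.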

Compound 4, half-maximal inhibitory concentration: 1070 nM
The estimate for compound 4 lay 1.8-fold (0.25 log units) below the measured number; low and high end bracket the measured number.
By their numbers in this assay, from the lowest: compound 3; then compounds 4 and 2 (each within the scatter of the next); then compound 1.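

In this assay, among these compounds, opening the dioxolane to the diol on a saturated chain carbon bound to an aromatic nitrogen gives a 2.1-fold higher number from compound 3 to compound 4 (0.33 log units; beyond the scatter), so this change at this place registers, if modestly, where the earlier compounds showed only a change of chain length. The 1-(2,3-dihydroxypropyl)-1H-1,2,3-triazol-4-yl side chain is also set apart from one methylpiperazine side chain, with a 3.6-fold lower number from compound 1 to compound 4 (0.55 log units; beyond the scatter), but not from the other, with a 1.5-fold lower number from compound 2 to compound 4 (0.19 log units; within the scatter), so the triazole-bearing side chain alone does not secure the lowest number. Nothing available explains the step from the dioxolane to the diol.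

As far as these compounds go, whether the step follows from the ring itself or from its two methyl groups stays open. So does how an amine in place of the diol, or a longer chain between the triazole and the diol, would read in this assay.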